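The compounds below may be only part of what the source reports. "The series", "measured", "known", "first", "only" and "open" are said of these compounds alone.

Compound 1 `CCCC(=O)N1CC2CC(C1)N2` carries a straight chain on the carbonyl carbon of the shared core. In an assay on CHO cells for agonist activity at Neuronal acetylcholine receptor; alpha3/alpha6/beta2/beta3 (Homo sapiens), read by FLIPR and calcium flux (on this read-out higher numbers stand for an effect only at larger amounts of compound and lower numbers for an effect already at smaller amounts), compound 1 gives 300 nM. Compound 2 `C[C@@H]1C[C@@H]1C(=O)N1CC2CC(C1)N2` has a small ring in place of that chain, and the shift is a 3.1-fold higher number from compound 1 to compound 2 (0.49 log units; beyond the scatter). On the two numbers shown, compound 2 stands at the weaker end: in this assay compound 2 gives 920 nM, and the only other compound, compound 1, sits at a lower number beyond the scatter.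

Compound 3 `C[C@@H]1C[C@H]1C(=O)N1CC2CC(C1)N2` has the same atoms and bonds as compound 2 and differs only in how one ring centre is drawn: the two compounds have the same atoms and bonds; at least one stereo element is drawn with a configuration in one of them and without one in the other: 1 of 4 stereo elements differ; a stereocentre at a saturated ring carbon is drawn S in compound 2 and R in compound 3. Going by the values given here, no measured step bears directly on such a change. Among the compounds with values here, the single step on record, from a chain to a ring on the carbonyl carbon, was modest, and it says nothing about how the two drawings of the ring centre compare. With nothing pointing in either direction, the number for compound 3 in this assay is expected to stay near that of compound 2, with wide uncertainty. The estimated step is a 1.2-fold lower number from compound 2 to compound 3 (0.06 log units; within the scatter). Compound 3 is therefore estimated at 800 nM, with a range from 200 nM to 3200 nM.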

Compound 3, half-maximal effective concentration: 51 nM
Estimate against measurement, compound 3: 16-fold (1.20 log units) above; measured number below the stated range.
By their numbers in this assay, from the lowest: compound 3; then compound 1; then compound 2.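

In this assay, redrawing one ring centre, with no atom or bond changed, gives an 18-fold lower number from compound 2 to compound 3 (1.26 log units; beyond the scatter), a large step that outweighs the modest one seen earlier between the straight chain and the ring. The earlier result therefore cannot be read as a general verdict on replacing propyl with 2-methylcyclopropyl on the carbonyl carbon: one drawing of the ring raised the number, while the other gives a 5.9-fold lower number from compound 1 to compound 3 (0.77 log units; beyond the scatter), so the direction of this replacement depends on the configuration of the ring. The gap between compound 2 and compound 3 can be tied to only one structural feature: the fact that one of compounds 2 and 3 is drawn with a defined configuration and the other without, at the place where they differ.

On these data alone, it remains open whether a plain cyclopropyl, a 2-ethylcyclopropyl or a longer chain such as pentyl on the carbonyl carbon would keep the low number of compound 3 or lose it. The compounds shown also leave open how the other ring centre of the 2-methylcyclopropyl group bears on the number, since only one centre changes between compound 2 and compound 3.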